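Thiocarbamate amine variation on the shared core

The compounds below may be only part of what the source reports. "The series", "measured", "known", "first", "only" and "open" are said of these compounds alone.

Compound 3 `COc1ccc2occ(CSC(=S)N3CCCC3)c(=O)c2c1` gives 34100 nM in a functional assay on MCF7 cells (Homo sapiens) for antiproliferative activity, read by MTT assay, with a stated time of 72 h (a lower number here means a stronger inhibitor, a higher number a weaker inhibitor), the highest of the two numbers in hand. Compound 2 `COc1ccc2occ(CSC(=S)N3CCOCC3)c(=O)c2c1` gives 11800 nM in this assay. For compound 1 `COc1ccc2occ(CSC(=S)N(C(C)C)C(C)C)c(=O)c2c1` this assay reports only a limit, > 40000 nM (the limit of > 40000 nM in this assay, at which 1 of the 3 values shown sits). Compound 4 `COc1ccc2occ(CSC(=S)N3CCCCC3)c(=O)c2c1` is not yet measured; it differs from compound 3 by piperidin-1-yl in place of pyrrolidin-1-yl on a thiocarbonyl carbon. The measured steps that bear on it are a 2.9-fold higher number from compound 2 to compound 3 (0.46 log units; beyond the scatter) and an at least 1.1-fold lower number from compound 1 to compound 3 (0.06 log units; that floor lies within the scatter), neither of which compares two saturated rings of different size, while an at least 3.3-fold lower number from compound 1 to compound 2 (0.53 log units; beyond the scatter) concerns a different change. A step within the scatter is therefore expected, a 1.1-fold lower number from compound 3 to compound 4 (0.06 log units; within the scatter). Compound 4 is estimated at 30000 nM in this assay, with a range from 10000 nM to 40000 nM.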

Compound 4, half-maximal inhibitory concentration: > 40000 nM
Compound 4 gave a limit, no number; the forecaster's own chance of this, stated with the estimate: 35%; middle value at least 1.3-fold (0.12 log units) away from the limit.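

In this assay, the change of ring size on a thiocarbonyl carbon gives an at least 1.1-fold higher number from compound 3 to compound 4 (0.06 log units; that floor lies within the scatter), so piperidin-1-yl cannot be separated from pyrrolidin-1-yl. Piperidin-1-yl in place of morpholin-4-yl gives the readable loss, an at least 3.3-fold higher number from compound 2 to compound 4 (0.53 log units; beyond the scatter). The step between compound 1 and compound 4 cannot be read, as compound 4, like compound 1, gives a limit and no number: the limit of > 40000 nM in this assay, at which 2 of the 4 values shown sit.

Open, as far as these compounds go, is whether any other amine on this carbon, such as 4-methylpiperazin-1-yl or dimethylamino, gives a lower number than compound 2. Also open, from the compounds shown here alone, is whether the order seen for compound 2 and compound 4 holds in other cell lines.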